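This account rests on a few compounds, and the source may have more. Where it says the series, first, only, none or still open, it means among the compounds named here.

Within the data shown here, compound 2 `O=C(CN1CCN(c2ccccc2F)CC1)Nc1nc2ccccc2[nH]1` gives 47.7% in a functional assay, read by spectrophotometry, with a stated time of 30 min, tested at 100 ug/mL (a higher number here means a stronger effect of the compound at the concentration tested, a lower number a weaker effect), the second highest of the three numbers known. Compound 1 `CCN1CCN(CC(=O)Nc2nc3ccccc3[nH]2)CC1` gives 45.7% and compound 3 `O=C(CN1CCN(c2ccccn2)CC1)Nc1nc2ccccc2[nH]1` gives 57.3%. The step to compound 4 `O=C(CN1CCN(c2ncccn2)CC1)Nc1nc2ccccc2[nH]1` is pyrimidin-2-yl in place of 2-fluorophenyl on an amine nitrogen in a ring. The measured step closest to it is a number 9.6 percentage points higher from compound 2 to compound 3 (within the scatter); the same place also shows a number 11.6 percentage points higher from compound 1 to compound 3 (beyond the scatter), whereas a number 2 percentage points higher from compound 1 to compound 2 (within the scatter). Because compound 3 gives 57.3% with a six-membered aromatic ring bearing nitrogen at this place, compound 4 is expected to land near compound 3 or somewhat above it. The expected change is therefore a number 7.3 percentage points higher from compound 2 to compound 4 (within the scatter), a step within the scatter. The estimate for compound 4 is 55%, with a range from 42% to 68%.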

Compound 4, a percentage reported as activity, at one concentration (the size of the read-out at that concentration, not a potency): 46.5%
Compound 4: middle estimate off by 8.5 percentage points, on the high side; the range from low to high includes it.
By their numbers in this assay, from the lowest: compounds 1, 4, 2 and 3 (each within the scatter of the next, the first and the last beyond it).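

At this place, on an amine nitrogen in a ring, the second ring nitrogen of pyrimidin-2-yl does not keep the level reached with pyridin-2-yl: in this assay the change gives a number 10.8 percentage points lower from compound 3 to compound 4 (beyond the scatter). Replacing 2-fluorophenyl gives a number 1.2 percentage points lower from compound 2 to compound 4 (within the scatter) and replacing ethyl gives a number 0.8 percentage points higher from compound 1 to compound 4 (within the scatter), so among these groups only pyridin-2-yl stands apart from ethyl. Nothing available explains the difference between these two rings. Going by these compounds, whether pyrazin-2-yl or pyridin-4-yl at the same nitrogen would match pyridin-2-yl remains open.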